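The source may hold more compounds than are shown below. What is called first, only, known or untested is meant among the compounds shown, and "the series" means these compounds.

Compound 1 `O=C(NS(=O)(=O)c1ccc(NCCSc2ccccc2)c([N+](=O)[O-])c1)c1ccc(NC(=O)c2ccccc2F)cc1` carries the shared core of this small set, and in an assay on isolated protein for binding affinity to Apoptosis regulator Bcl-2 (Homo sapiens), read by fluorescence polarization (on this read-out lower numbers stand for stronger inhibition and higher numbers for weaker inhibition), compound 1 gives 1090 nM. Compound 2 `CC[C@H](C)[C@H](NC(C)=O)C(=O)Nc1ccc(C(=O)NS(=O)(=O)c2ccc(NCCSc3ccccc3)c([N+](=O)[O-])c2)cc1` gives 3380 nM in this assay, and compound 3 `CC(=O)N[C@@H](CC(C)C)C(=O)Nc1ccc(C(=O)NS(=O)(=O)c2ccc(NCCSc3ccccc3)c([N+](=O)[O-])c2)cc1` gives 3780 nM. Compound 3 has the highest number of the three; its value and that of compound 2 lie within the scatter of each other, while compound 1 stands apart, as the step of a 3.5-fold higher number from compound 1 to compound 3 (0.54 log units; beyond the scatter) shows. The parallel step a 3.1-fold higher number from compound 1 to compound 2 (0.49 log units; beyond the scatter) is of similar size, and the step of a 1.1-fold higher number from compound 2 to compound 3 (0.05 log units; within the scatter) stays within the scatter.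

Compound 4 `CC(=O)N[C@H](C(=O)Nc1ccc(C(=O)NS(=O)(=O)c2ccc(NCCSc3ccccc3)c([N+](=O)[O-])c2)cc1)C(C)C` has not yet been measured in this assay. Its change from compound 3 is isopropyl in place of isobutyl on a saturated chain carbon bound to an amide-type nitrogen and a carbonyl carbon. The measured step that bears most directly on it is a 1.1-fold higher number from compound 2 to compound 3 (0.05 log units; within the scatter), in which one saturated branched chain replaced another on the same carbon without a shift beyond the scatter. The steps from compound 1 describe a different change and are only a loose guide. On that basis no step beyond the scatter is expected for compound 4 in this assay, the expected step being a 1.1-fold higher number from compound 3 to compound 4 (0.02 log units; within the scatter). Compound 4 is therefore estimated at 4000 nM, with a range from 2000 nM to 8500 nM.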

Compound 4, inhibition constant: 9490 nM
The estimate for compound 4 lay 2.4-fold (0.38 log units) below the measured number; measured number outside the range, above it.
By their numbers in this assay, from the lowest: compound 1; then compounds 2 and 3 (each within the scatter of the next); then compound 4.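

In this assay, the position on a saturated chain carbon bound to an amide-type nitrogen and a carbonyl carbon proves sensitive to which branched chain it carries: isopropyl in place of isobutyl gives a 2.5-fold higher number from compound 3 to compound 4 (0.40 log units; beyond the scatter), a shift beyond the scatter, which the within-scatter exchange of sec-butyl for isobutyl had not suggested. Hydrogen in place of methyl gives a shift of similar size, a 2.8-fold higher number from compound 2 to compound 4 (0.45 log units; beyond the scatter), so isopropyl parts from both of the other saturated chains rather than from isobutyl alone. The replacement of 2-fluorophenyl thus depends on the chain carried by the acetamido-bearing carbon, and with 1-acetamido-2-methylpropyl it reaches an 8.7-fold higher number from compound 1 to compound 4 (0.94 log units; beyond the scatter), which leaves compound 4 with the highest number of the four.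

Nothing presented here gives a measured reason for the weaker result with isopropyl. Still open, on these data alone, is how the same carbon would respond to a straight n-butyl chain, a cyclohexyl ring or a chain ending in a carboxylic acid, and whether any such group would bring the number back toward that of compound 1.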